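Chloro for Methyl on the Aryl Azetidinone

A few compounds are considered here, and "the series" means these few. Any claim that something is new, unique, unknown or untested is made for them only; others in the source may bear on it.

Measured compounds:
compound 1 `O=C(NO)c1ccc(COC(=O)N2CCC(N3CC(c4ccccc4)(c4ccccc4)C3=O)CC2)cc1` – 18.5 nM
compound 2 `Cc1cccc(C2CC(=O)N2C2CCN(C(=O)NCc3ccc(C(=O)NO)cc3)CC2)c1` – 399 nM

Two compounds have been characterised in an assay on Sf9 cells for inhibition of protein deacetylase HDAC6 (Homo sapiens), read by fluorescence, with a stated time of 90 min; on this read-out lower numbers stand for stronger inhibition and higher numbers for weaker inhibition. Compound 1 `O=C(NO)c1ccc(COC(=O)N2CCC(N3CC(c4ccccc4)(c4ccccc4)C3=O)CC2)cc1` gives 18.5 nM in this assay. Compound 2 `Cc1cccc(C2CC(=O)N2C2CCN(C(=O)NCc3ccc(C(=O)NO)cc3)CC2)c1` gives 399 nM in this assay, the higher of the two numbers, so it stands as the weaker inhibitor of the pair; the gap to compound 1 lies well beyond the scatter of repeated measurements.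

Compound 3 `O=C(NO)c1ccc(CNC(=O)N2CCC(N3C(=O)CC3c3cccc(Cl)c3)CC2)cc1` has not yet been measured. It differs from compound 2 in one place: chloro in place of methyl on an aromatic carbon of a six-membered aromatic ring of carbon only, meta to a large group. Among the measured compounds shown here, no measured pair in this set shows the effect of such a swap, so there is no step to lean on. For a single-atom exchange of this kind the expectation is a step no larger than the scatter, in either direction, which gives a 1.2-fold lower number from compound 2 to compound 3 (0.10 log units; within the scatter) as the expected step. Compound 3 is accordingly expected to give about 320 nM in this assay, within a range of 120 nM to 900 nM.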

Compound 3, half-maximal inhibitory concentration: 270 nM
The estimate for compound 3 lay 1.2-fold (0.07 log units) above the measured number, within the range that was stated.
By their numbers in this assay, from the lowest: compound 1; then compounds 3 and 2 (each within the scatter of the next).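

In this assay, chloro in place of methyl on an aromatic carbon gives a 1.5-fold lower number from compound 2 to compound 3 (0.17 log units; within the scatter), so the 3-methylphenyl and 3-chlorophenyl forms cannot be told apart on this read-out. Among the compounds shown here, this is the first step in the set that isolates this position, and it shows that activity stays within the scatter across this one exchange, while compound 1 differs from both compounds in more than one place and so says nothing about this position. Nothing available here accounts for the closeness of the two values.

From the compounds shown here alone, the two groups compared each hold a single heavy atom and have no hydrogen-bond donors or acceptors, so it remains open whether the position would respond to a different kind of group, such as an amine, a carboxylic acid or a longer chain, or to a plain hydrogen. Going by these compounds, it is also open whether the same exchange would give a similar result on the core of compound 1, and which of the several differences between that compound and compound 2 accounts for the gap between them.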